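This account rests on a few compounds, and the source may have more. Where it says the series, first, only, none or still open, it means among the compounds named here.

Among the compounds with values here, compound 1 `c1ccc(-c2ccc(Cn3cncc3CNc3cccc(-c4ccccc4)c3)cc2)cc1` is the only member of this set with a number in a toxicity assay on NIH3T3 cells (Mus musculus) for cytotoxicity, read by resazurin assay (a higher number here means that more compound is needed for the effect, a lower number that less compound is needed), where compound 1 gives 10000 nM. Compound 2 `c1ccc(-c2ccc(Cn3cncc3CNc3ccc(-c4ccc[nH]4)c(-c4ccccc4)c3)cc2)cc1` reaches only the limit of the assay, > 10000 nM. Compound 3 `c1ccc(-c2ccc(Cn3cncc3CNc3ccc(-c4cc5ccccc5o4)c(-c4ccccc4)c3)cc2)cc1` likewise reaches only the limit, > 10000 nM. The measured steps of a number no lower from compound 1 to compound 2 (the limit leaves the size open) and a number no lower from compound 1 to compound 3 (the limit leaves the size open) concern additions on a different aromatic carbon of the shared core, and what they show is the limit of > 10000 nM in this assay, at which 2 of the 3 values shown sit. Compound 4 `Cc1ccc(Cn2cncc2CNc2cccc(-c3ccccc3)c2)cc1` differs from compound 1 by methyl in place of phenyl on an aromatic carbon. Within the data shown here, no measured step touches this place, so no movement beyond the usual scatter is expected in this assay. The estimate for compound 4 is 10000 nM, with a range from 4000 nM to 25000 nM. This corresponds to an expected step of no change at the digits printed from compound 1 to compound 4 (within the scatter).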

Compound 4, half-maximal effective concentration: 10000 nM
Beside the measured number, compound 4's estimate shows no gap at the digits printed; low and high end bracket the measured number.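

In this assay, methyl in place of phenyl gives no change at the digits printed from compound 1 to compound 4 (within the scatter). Within the data shown here, this is the first step at this place, on an aromatic carbon para to a large group, and it shows that removing the six-membered aromatic ring there leaves the reading unmoved. How much room the step had to show a rise remains uncertain, because the other values stop at a limit: the limit of > 10000 nM in this assay, at which 2 of the 4 values shown sit.

The compounds shown leave open whether an amine or a carboxylic acid at this place would also leave the reading unmoved.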